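The source may hold more compounds than are shown below. What is called first, only, known or untested is meant among the compounds shown, and "the series" means these compounds.

Compound 1 `Nc1ncn(CCC2(N)OC(=O)C(OCc3ccccc3)=C2OCc2ccccc2)c(=O)n1`: in an ADME assay on WI-38 cells (Homo sapiens) for inhibition, read by MTT assay, with a stated time of 72 h (a lower number here means a stronger inhibitor, a higher number a weaker inhibitor), compound 1 gives > 100000 nM, a limit of the assay rather than a number.
Compound 2 `Nc1ccn(CCC2(N)OC(=O)C(OCc3ccccc3)=C2OCc2ccccc2)c(=O)n1`: in this assay compound 2 gives 88900 nM.
Compound 3 `Cc1cn(CCC2(N)OC(=O)C(OCc3ccccc3)=C2OCc2ccccc2)c(=O)[nH]c1=O`: in this assay compound 3 gives > 100000 nM, again only a limit.

Compound 3 therefore stands at the edge of what this assay can report, and the limit of > 100000 nM in this assay, at which 2 of the 3 values shown sit, shows it is not alone there. Compound 4 `NC1(CCn2c(=O)[nH]c(=O)[nH]c2=O)OC(=O)C(OCc2ccccc2)=C1OCc1ccccc1` differs from compound 3 by a group of 9 heavy atoms (3 carbon, 3 nitrogen, 3 oxygen; one six-membered aromatic ring with 3 hetero atoms) in place of a group of 9 heavy atoms (5 carbon, 2 nitrogen, 2 oxygen; one six-membered aromatic ring with 2 hetero atoms), on a saturated chain carbon, two bonds along the chain from a saturated ring carbon. The measured steps give little guidance: a step that the two limits leave unreadable from compound 1 to compound 3 is unreadable because both values are limits, and an at least 1.1-fold higher number from compound 2 to compound 3 (0.05 log units; that floor lies within the scatter) lies within the scatter. Nothing in these three compounds suggests that swapping one ring for another at this chain position moves the number beyond the scatter, so compound 4 is expected to remain at or near the limit. Compound 4 is estimated at 150000 nM, with a range from 60000 nM to 400000 nM. The expected step is a step that the limit leaves unreadable from compound 3 to compound 4.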

Compound 4, half-maximal inhibitory concentration: > 100000 nM
Compound 4 ended at the assay's limit; the forecaster's own chance of this, stated with the estimate: 70%; the middle value is on the limit's open side.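

Compound 4 has a ring with one more hydrogen-bond donor than the ring it replaces, yet it reaches the same limit as compound 3, and the limit now holds most of this small set: the limit of > 100000 nM in this assay, at which 3 of the 4 values shown sit. Within the data shown here, the one step that can be read is an at least 1.1-fold higher number from compound 2 to compound 4 (0.05 log units; that floor lies within the scatter), and the steps between compounds both at the limit cannot be read.

On these data alone, how far these compounds lie past the limit remains unknown. As far as these compounds go, whether an amine or a carboxylic acid in place of the ring, or a longer chain, would give a readable number also stays open.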